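Changing the Carbonyl Substituent on a Shared Core

The source may hold more compounds than are shown below. What is called first, only, known or untested is meant among the compounds shown, and "the series" means these compounds.

Compound 1 `CON(C)C(=O)C1(S(=O)(=O)c2ccc(Oc3ccc(OC(F)(F)F)cc3)cc2)CCC2(CCNCC2)C1` has the higher of the two numbers measured in a functional assay on blood (Homo sapiens), with a stated time of 60 min, in the presence of a further agent that is not named here (on this read-out higher numbers stand for an effect only at larger amounts of compound and lower numbers for an effect already at smaller amounts), where compound 1 gives 3700 nM. Among the compounds with values here, its only measured neighbour, compound 2 `O=C(Oc1ccccc1)C1(S(=O)(=O)c2ccc(Oc3ccc(OC(F)(F)F)cc3)cc2)CCC2(CCNCC2)C1`, gives 900 nM in this assay. Within the data shown here, the single measured step, a 4.1-fold lower number from compound 1 to compound 2 (0.61 log units; beyond the scatter), comes from one change on the carbonyl carbon, phenoxy in place of methoxy(methyl)amino.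

Compound 3 `O=C(Nc1nccs1)C1(S(=O)(=O)c2ccc(Oc3ccc(OC(F)(F)F)cc3)cc2)CCC2(CCNCC2)C1` has not yet been measured. It differs from compound 1 at the same carbonyl carbon: (1,3-thiazol-2-yl)amino in place of methoxy(methyl)amino on a carbonyl carbon. The step from compound 1 to compound 2 is the only one that bears on this change, since it also removes the methoxy(methyl)amino group from that carbon, and it lowered the number by a modest amount beyond the scatter. Whether an aromatic amine at this position behaves like a phenoxy group is not shown by the data, so the expectation is tentative. A modest step in the same direction, a 3.1-fold lower number from compound 1 to compound 3 (0.49 log units; beyond the scatter), is expected for compound 3. Compound 3 is therefore estimated at 1200 nM in this assay, within a range from 350 nM to 4000 nM.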

Compound 3, half-maximal effective concentration: > 15000 nM
Compound 3: no number, only a limit; the forecaster's own chance of this, stated with the estimate: 5%; middle value at least 12-fold (1.09 log units) away from the limit.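

Within the data shown here, at this carbonyl carbon, the group can move the number up as well as down: the earlier compounds showed only a fall, whereas the new result gives an at least 4.0-fold higher number from compound 1 to compound 3 (0.60 log units; beyond the scatter), and the gap to the phenoxy compound is wider still, an at least 16-fold higher number from compound 2 to compound 3 (1.22 log units; beyond the scatter). So an aromatic ring attached through a nitrogen that carries a hydrogen does not simply repeat what phenoxy did, and having a ring at this place does not by itself bring the number down. In this assay, compound 3 gives only a limit and not a number: the limit of > 15000 nM in this assay, at which 1 of the 3 values shown sits.

The compounds shown do not tell whether the rise follows the five-membered aromatic ring, its hetero atoms or the amide hydrogen, and how far compound 3 lies past its limit also stays open. A phenylamino group, which keeps the amide hydrogen with a plain benzene ring, or a methylamino group, which keeps that hydrogen with no ring at all, on the same carbonyl carbon of the shared core would be the comparisons that could start to separate these parts.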